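The source may hold more compounds than are shown below. What is called first, only, known or untested is meant among the compounds shown, and "the series" means these compounds.

Compound 1 `CN(C)CCCCCCCCOc1ccc2oc(-c3ccccc3)cc(=O)c2c1`: 143 nM. Compound 2 `O=c1cc(-c2ccccc2)oc2ccc(OCCCN3CCC(O)CC3)cc12`: 123 nM. Compound 3 `O=c1cc(-c2ccccc2)oc2ccc(OCCCCCCN3CCCCC3)cc12`: 54 nM.

In an assay on isolated protein (Cavia porcellus) with Sigma non-opioid intracellular receptor 1 (Homo sapiens) as the target, read by radioligand binding (a higher number here means a weaker inhibitor, a lower number a stronger inhibitor), compound 3 stands lowest of the three, and both other numbers lie beyond the scatter from it. Compound 4 `NCCCCCCOc1ccc2oc(-c3ccccc3)cc(=O)c2c1` differs from compound 3 by amino in place of piperidin-1-yl on a saturated chain carbon, six bonds along the chain from an oxygen on an aromatic ring. Within the data shown here, two measured steps bear on this. The step of a 2.6-fold lower number from compound 1 to compound 3 (0.42 log units; beyond the scatter) replaces one amine head with another at the same place, and the step of a 2.3-fold lower number from compound 2 to compound 3 (0.36 log units; beyond the scatter) alters chain and amine together. In both, compound 3 with its piperidin-1-yl group gives the lower number. Cutting that ring down to a bare amino group in compound 4 is therefore expected to move the number modestly upward, by a 2.8-fold higher number from compound 3 to compound 4 (0.44 log units; beyond the scatter). Compound 4 is estimated at 150 nM, within a range from 60 nM to 400 nM.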

Compound 4, half-maximal inhibitory concentration: 3700 nM
Estimate against measurement, compound 4: 25-fold (1.39 log units) below, outside the stated range (above it).
By their numbers in this assay, from the lowest: compound 3; then compounds 2 and 1 (each within the scatter of the next); then compound 4.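

In this assay, among these compounds, replacing piperidin-1-yl with amino at this place gives a 69-fold higher number from compound 3 to compound 4 (1.84 log units; beyond the scatter), a far larger change than any among the earlier compounds. The bare amino group also sets compound 4 apart from the other two amine heads, with a 30-fold higher number from compound 2 to compound 4 (1.48 log units; beyond the scatter) and a 26-fold higher number from compound 1 to compound 4 (1.41 log units; beyond the scatter), although compounds 1 and 2 lie within the scatter of each other. No evidence here accounts for the size of this change.

The compounds shown leave open whether a methylamino group or a pyrrolidin-1-yl ring at this place would bring the number back down. They also leave open what the amino group does on a shorter chain.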